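This account rests on a few compounds, and the source may have more. Where it says the series, first, only, none or still open, it means among the compounds named here.

Compound 1 `CCCCCCCCCCCO[C@@H]1[C@@H](N)[C@@H](O[C@H]2[C@H](O)[C@@H](OCCCCCCC)[C@H](N)C[C@@H]2N)O[C@H](CN)[C@H]1O`: 88.4%
Compound 2 `CCCCCCCCCCCO[C@@H]1[C@@H](N)[C@@H](O[C@H]2[C@H](O)[C@@H](O)[C@H](N)C[C@@H]2N)O[C@H](CN)[C@H]1O`: 81.8%
Compound 3 `CCCCCCCCCCCO[C@@H]1[C@@H](O)[C@H](O[C@H]2O[C@H](CN)[C@@H](O)[C@H](OCCCCCCC)[C@H]2N)[C@@H](N)C[C@H]1N`: 82.9%

In an ADME assay on J774 cells (Mus musculus) for cytotoxicity, read by MTT assay, with a stated time of 24 h, tested at 10 uM (a lower number here means a stronger effect, a higher number a weaker effect of the compound at the concentration tested), compound 3 stands second highest of the three, with compound 2 nearest and compound 1 furthest, both within the scatter. Compound 4 `CCCCCCCCCCCO[C@@H]1[C@@H](N)[C@@H](O[C@H]2[C@H](O)[C@@H](OCCCCCCCCCCC)[C@H](N)C[C@@H]2N)O[C@H](CN)[C@H]1O` differs from compound 3 by butyl in place of hydrogen on a saturated chain carbon, seven bonds along the chain from an oxygen on a saturated carbon. Among the measured compounds shown here, the one measured step that bears on an alkyl chain on this oxygen is a number 6.6 percentage points lower from compound 1 to compound 2 (within the scatter), which lies within the scatter. Lengthening rather than removing the chain is therefore expected to move this assay little, with no step beyond the scatter in either direction. The step from compound 3 to compound 4 is estimated at a number 2.1 percentage points higher from compound 3 to compound 4 (within the scatter). Compound 4 is expected to give 85% in this assay, within a range from 72% to 96%.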

Compound 4, a percentage reported as activity, at one concentration (the size of the read-out at that concentration, not a potency): 81.7%
For compound 4 the middle estimate is 3.3 percentage points above the measured one; the measured number falls inside the stated range.
By their numbers in this assay, from the lowest: compounds 4, 2, 3 and 1 (each within the scatter of the next).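

In this assay, butyl in place of hydrogen, seven bonds along the chain from the oxygen, stays within the scatter in both cases that can be read (a number 1.2 percentage points lower from compound 3 to compound 4 (within the scatter)) (a number 6.7 percentage points lower from compound 1 to compound 4 (within the scatter)). Undecyl in place of hydrogen on this oxygen also stays within the scatter (a number 0.1 percentage points lower from compound 2 to compound 4 (within the scatter)), so this position tolerates the longer chain as well as the free oxygen at this one concentration. Nothing available explains this result. On these data alone, it remains open whether a longer chain, or an amine at the end of the chain, on this oxygen would give a lower number in this assay.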